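The compounds below may be only part of what the source reports. "The series", "measured", "known", "first", "only" and "open" are said of these compounds alone.

Among the measured compounds shown here, only two compounds have numbers so far in a physicochemical assay for solubility, measured as kinetic solubility, at pH 2; on this read-out lower numbers stand for lower solubility and higher numbers for higher solubility. Compound 1 (`CC(C)[C@@H](c1ccc(-c2ccc3cccc(F)c3c2)[nH]c1=O)[C@@H]1OC(=O)NC1=O`) gives 6900 nM, and compound 2 (`CCn1ncc2c(F)cc(-c3ccc(C(/C=C4\OC(=O)NC4=O)(CC)CC)c(=O)[nH]3)cc21`) gives 21700 nM. Compound 1 therefore holds the lower of the two numbers, and its gap to compound 2 lies beyond the usual scatter. Compound 3 (`CC(C)[C@@H](c1ccc(-c2ccc3cccc(F)c3c2)[nH]c1=O)[C@H]1OC(=O)NC1=O`) has not yet been measured in this assay. Its relation to compound 1 is the two compounds have the same atoms and bonds and differ only in configuration as drawn: 1 of 2 stereo elements differ; a stereocentre at a saturated ring carbon is drawn S in compound 1 and R in compound 3: the two compounds have the same atoms and bonds and differ only in configuration as drawn, with a stereocentre at a saturated ring carbon drawn S in compound 1 and R in compound 3. For the measured compounds named here, no measured pair isolates a change of configuration, so the data offer no precedent for this step. In this assay, the expected result is a 1.0-fold higher number from compound 1 to compound 3 (0.01 log units; within the scatter), an estimated change that stays within the scatter, with no direction favoured. For compound 3 the estimate is 7000 nM, with an expected range from 3200 nM to 15000 nM.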

Compound 3, solubility: 5400 nM
Compound 3: middle estimate off by 1.3-fold (0.11 log units), on the high side; the range from low to high includes it.
By their numbers in this assay, from the lowest: compounds 3 and 1 (each within the scatter of the next); then compound 2.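

Among the compounds shown here, this is the first pair that isolates a single change of configuration, at a saturated ring carbon: the fact that compounds 1 and 3 differ only in the configuration as drawn. In this assay, the stereocentre drawn S in compound 1 and R in compound 3 gives a 1.3-fold lower number from compound 1 to compound 3 (0.11 log units; within the scatter), so this change of configuration does not separate the two compounds on this read-out. As a single pair on the core of compound 1, the result speaks for this stereocentre only, while the second stereo element stays as drawn in both compounds.

Still open, going by these compounds, is whether changing that second stereo element, alone or together with the first, would also leave the number in this assay within the scatter. Also open, on these data alone, is whether the same change of configuration would stay within the scatter on a core carrying a further group, such as an amine or a carboxylic acid, since the step here was read with only one set of substituents around the stereocentre.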